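Iodo on the diethylamino member of the series

The source may hold more compounds than are shown below. What is called first, only, known or untested is meant among the compounds shown, and "the series" means these compounds.

Compound 1 `COc1cc(Nc2nccc(NCCCN)n2)cc(OC)c1OC`: > 50000 nM, a limit
Compound 2 `COc1cc(Nc2ncc(I)c(NCCCN)n2)cc(OC)c1OC`: 39900 nM
Compound 3 `CCN(CC)CCNc1ccnc(Nc2cc(OC)c(OC)c(OC)c2)n1`: > 50000 nM, a limit

In a functional assay on U-937 cells (Homo sapiens) for antiproliferative activity, read by MTT assay, with a stated time of 24 h (a lower number here means a stronger inhibitor, a higher number a weaker inhibitor), compound 3 has only a limit, > 50000 nM. That places it at the limit of > 50000 nM in this assay, at which 2 of the 3 values shown sit. Compound 4 `CCN(CC)CCNc1nc(Nc2cc(OC)c(OC)c(OC)c2)ncc1I` carries iodo in place of hydrogen on an aromatic carbon. The same exchange was measured once, as an at least 1.2-fold lower number from compound 1 to compound 2 (0.09 log units; that floor lies within the scatter). As far as these compounds go, the start of that step is a limit, so its true size stays open. The other measured step is a step that the two limits leave unreadable from compound 1 to compound 3, which gives no size. A modest lowering in this assay is therefore expected, though compound 4 may also return only a limit. The expected step is an at least 1.4-fold lower number from compound 3 to compound 4 (0.15 log units; that floor lies within the scatter). For compound 4 the estimate is 35000 nM, with an expected range of 14000 nM to 60000 nM.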

Compound 4, half-maximal inhibitory concentration: 22000 nM
Compound 4: middle estimate off by 1.6-fold (0.20 log units), on the high side; measured number inside the range.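

In this assay, iodo on the aromatic carbon two atoms from the ring nitrogen now gives a step beyond the scatter, an at least 2.2-fold lower number from compound 3 to compound 4 (0.35 log units; beyond the scatter), which the earlier pair could not show. With iodo in place, the diethylamino exchange gives a 1.8-fold lower number from compound 2 to compound 4 (0.26 log units; within the scatter), so compound 2 and compound 4 cannot be separated. The change now stands on two cores: the same change on two cores in this assay, an at least 1.2-fold lower number (0.09 log units; that floor lies within the scatter) from compound 1 to compound 2 and an at least 2.2-fold lower number (0.35 log units; beyond the scatter) from compound 3 to compound 4; the limit leaves it open whether they differ.

As far as these compounds go, whether bromo or methyl on that carbon would give a comparable number stays open. So does the true size of the iodo step on each core, as compound 1 and compound 3 have only limits.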